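Isopropoxy in place of amino on a carbonyl carbon

The source may hold more compounds than are shown below. What is called first, only, known or untested is meant among the compounds shown, and "the series" means these compounds.

Of the compounds shown here, two with a shared core have numbers so far in an ADME assay on Jurkat cells (Homo sapiens) for cytotoxicity, read by MTT assay, with a stated time of 72 h (on this read-out higher numbers stand for weaker inhibition and lower numbers for stronger inhibition), so far. Compound 1 (`COC(=O)c1cnc(Oc2ccc3c(c2)B(O)OC3)cn1`) gives 7590 nM and compound 2 (`NC(=O)c1cnc(Oc2ccc3c(c2)B(O)OC3)cn1`) gives 48200 nM as the higher of the two numbers, which places compound 2 on the weaker side of this small set.

Compound 3 (`CC(C)OC(=O)c1cnc(Oc2ccc3c(c2)B(O)OC3)cn1`) has not been measured. Its difference from compound 2 is isopropoxy in place of amino on a carbonyl carbon and in words it is isopropoxy in place of amino on a carbonyl carbon.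

For the measured compounds named here, only one measured step bears on this change. It is a 6.4-fold higher number from compound 1 to compound 2 (0.80 log units; beyond the scatter) with amino in place of methoxy on a carbonyl carbon, a modest step. Compound 3 also loses the amino, so that step may largely run backwards, although no measurement shows how isopropoxy compares with methoxy. That reasoning points towards compound 1 at 7590 nM as the nearest guide. In this assay the expected result is a 7.4-fold lower number from compound 2 to compound 3 (0.87 log units; beyond the scatter) as a modest step towards a lower number. The estimate for compound 3 is 6500 nM (expected range 2500 nM to 17000 nM).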

Compound 3, half-maximal inhibitory concentration: > 100000 nM
Compound 3: no number, only a limit; the forecaster's own chance of this, stated with the estimate: 3%; middle value at least 15-fold (1.18 log units) from the limit.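

Compound 3 has no exact number in this assay, only a limit of the assay: the limit of > 100000 nM in this assay, at which 1 of the 3 values shown sits.

The clearest new finding is an at least 13-fold higher number from compound 1 to compound 3 (1.11 log units; beyond the scatter), with isopropyl in place of methyl on an oxygen next to a carbonyl group, so a change confined to the alkyl part of the ester is enough to shift the read-out strongly at this position. The other step is an at least 2.0-fold higher number from compound 2 to compound 3 (0.31 log units; beyond the scatter), with isopropoxy in place of amino on a carbonyl carbon, and it shows that losing the amino does not by itself bring the number down, since compound 1 and compound 3 both lack it yet lie on opposite sides of compound 2.

The limit leaves open how much higher the true value of compound 3 lies, and therefore the full size of both steps. Also open, from the compounds shown here alone, is how the read-out changes between methoxy and isopropoxy, and whether an ethoxy group on the same carbonyl carbon, a longer chain on that oxygen or a carboxylic acid would fall nearer compound 1 or compound 3.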